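The compounds below may be only part of what the source reports. "The series", "measured", "known", "first", "only" and "open" are said of these compounds alone.

Working notes on the pyrazole chalcone series.

Three compounds have numbers in a functional assay on KM12 cells (Homo sapiens) for inhibition, read by sulforhodamine B assay, with a stated time of 48 h (on this read-out lower numbers stand for stronger inhibition of growth and higher numbers for weaker inhibition of growth), so far. Compound 1 `COc1cc(-c2cc(/C=C/C(=O)c3ccc(N)cc3)[nH]n2)cc(OC)c1OC` gives 2880 nM. Compound 2 `COc1ccc(-c2cc(/C=C/C(=O)c3cc(OC)c(OC)c(OC)c3)[nH]n2)cc1OC` gives 2270 nM, and compound 3 `COc1ccc(-c2cc(/C=C/C(=O)c3ccc(N)cc3)[nH]n2)cc1` gives 3420 nM. The three numbers lie within the usual scatter of one another, so compound 1 stands neither apart from compound 2 nor from compound 3; the set reads as a single level of growth inhibition, with no ordering that the data can support.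

The next compound, compound 4 `COc1ccc(C(=O)/C=C/c2cc(-c3cc(OC)c(OC)c(OC)c3)n[nH]2)cc1`, is to be measured in this assay. It differs from compound 1 in one place: methoxy in place of amino on an aromatic carbon. Compound 2 carries a trimethoxy-substituted ketone aryl in place of the aminophenyl of compound 1 and its value sits within the scatter of compound 1, which is the only hint available on what an exchange at this ring does here. Among the measured compounds shown here, no single-point step between measured compounds exists for this change, so the expectation rests on that comparison alone. The step in this assay is expected to be small, with no direction beyond the scatter. The expected step is a 1.0-fold lower number from compound 1 to compound 4 (0.01 log units; within the scatter). Compound 4 is estimated at 2800 nM, with a range from 1200 nM to 6500 nM.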

Compound 4, concentration for total growth inhibition: 3060 nM
Estimate against measurement, compound 4: 1.1-fold (0.04 log units) below, within the range that was stated.
By their numbers in this assay, from the lowest: compounds 2, 1, 4 and 3 (each within the scatter of the next).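

In this assay, among the compounds shown here, the exchange of 4-aminophenyl for 4-methoxyphenyl provides the only step that changes one place, and therefore the only direct reading at this position (a 1.1-fold higher number from compound 1 to compound 4 (0.03 log units; within the scatter)). The earlier compounds shown here gave only an indirect hint about this ring, whereas this pair shows that, on the core of compound 1, amino can be replaced by methoxy without taking the number outside the scatter, even though the hydrogen-bond donor of amino is absent from methoxy. No measurement in hand bears on why this step stays so small.

A single exchange says little about the range of groups tolerated on this aromatic carbon, so a carboxylic acid, a dimethylamino group or a longer chain such as butoxy would each be an informative test of whether the flat reading extends beyond amino and methoxy. On these data alone, it also remains open whether amino and methoxy would read alike on a core with a different substitution pattern, since this pair gives the comparison on one core only.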